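The source may report more compounds than this note shows. Statements on the series, on what has been measured and on what is new or still open speak of the compounds shown alone.

In a functional assay on HL-60 cells (Homo sapiens) for cytotoxicity, read by MTT assay, with a stated time of 4 days (on this read-out lower numbers stand for stronger inhibition and higher numbers for weaker inhibition), the measured compounds stand as follows:

compound 1 `Cc1c(O)ccc2c1[C@H](Cn1cc(-c3ccc(F)cc3)nn1)[C@@]13CC(=O)[C@@](C)(CC[C@@H]21)C3`: > 20000 nM, a limit of the assay rather than a number
compound 2 `Cc1ccc(S(=O)(=O)Oc2ccc3c(c2C)[C@H](Cn2cc(-c4ccc(Cl)cc4)nn2)[C@@]24CC(=O)[C@@](C)(CC[C@@H]32)C4)cc1`: > 20000 nM, again a limit of the assay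
compound 3 `C=C1C[C@]23C[C@@]1(O)CC[C@@H]2c1cccc(C)c1[C@@H]3Cn1cc(-c2ccc(OC)cc2)nn1`: > 20000 nM, also a limit of the assay

Compound 3 therefore has no number of its own in this assay, only a limit, and it shares this position with the two other compounds, since (the limit of > 20000 nM in this assay, at which 3 of the 3 values shown sit). Going by the values given here, no step between two measured compounds is available to set a scale for what a change of the aryl group on the triazole does here.

Compound 4 `C=C1C[C@]23C[C@@]1(O)CC[C@@H]2c1cccc(C)c1[C@@H]3Cn1cc(-c2ccc(F)cc2)nn1` differs from compound 3 by fluoro in place of methoxy on an aromatic carbon. With three limits and nothing else to go on, the step from compound 3 to compound 4 is expected to be none beyond the scatter, which is to say a step that the limit leaves unreadable from compound 3 to compound 4. For compound 4 in this assay the estimate is 30000 nM, within a range from 10000 nM to 100000 nM, and it is expected that the assay will most likely again report only a limit.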

Compound 4, half-maximal inhibitory concentration: > 20000 nM
Compound 4: no number, only a limit; the forecaster's own chance of this, stated with the estimate: 85%; the middle value is on the limit's open side.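

Compound 3 and compound 4 both sit at a limit of the assay, so no step can be read between them, and the change from 4-methoxyphenyl to 4-fluorophenyl has no readable size. The compounds shown leave open what any single change does to cytotoxicity in this assay.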